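The compounds below may be only part of what the source reports. "The series", "measured", "known", "first", "only" and "open" are said of these compounds alone.

Working notes on the series. The parent, compound 1 `COc1cc2c(cc1OC)C(CC(N)=O)CC2`, carries a primary amide, and in a functional assay on the whole organism (strain Wistar) for inhibition, with Rattus norvegicus as the target, read by paw edema, with stated times of 60 min and 4 h, at a dose of 100 mg/kg by the oral route (a higher number here means more inhibition at the dose given (going by the name of the read-out), a lower number less inhibition), compound 1 gives 31.3%. Among the measured compounds shown here, compound 2 `COc1cc2c(cc1OC)C(CC(=O)NCc1ccccc1)CC2` places a benzyl group on the amide nitrogen, and in this assay compound 2 gives 18.8%, the lowest of the two numbers so far; the step of a number 12.5 percentage points lower from compound 1 to compound 2 (beyond the scatter) is beyond the scatter but modest. Compound 3 `COc1cc2c(cc1OC)C(CC(=O)NCCO)CC2` differs from compound 2 by hydroxymethyl in place of phenyl on a saturated chain carbon bound to an amide-type nitrogen. For the measured compounds named here, the only measured step that touches this position is the one from compound 1 to compound 2, and it replaced hydrogen, not phenyl, so it bears on the new step only loosely. With no closer comparison, a change within the scatter is expected, perhaps a small recovery toward compound 1. For compound 3 the estimate is 24%, with a range of 10% to 38%, meaning an expected step of a number 5.2 percentage points higher from compound 2 to compound 3 (within the scatter).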

Compound 3, a percentage reported as inhibition, in the whole organism at one dose (the size of the read-out at that dose, not a potency): 9.37%
Estimate against measurement, compound 3: 14.6 percentage points above; measured number below the stated range.
By their numbers in this assay, from the lowest: compounds 3 and 2 (each within the scatter of the next); then compound 1.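

In this assay the step of a number 9.4 percentage points lower from compound 2 to compound 3 (within the scatter) shows that hydroxymethyl in place of phenyl on the saturated chain carbon bound to the amide-type nitrogen leaves the number within the scatter, so the aromatic ring of compound 2 is not required for the level seen there. The step of a number 21.9 percentage points lower from compound 1 to compound 3 (beyond the scatter) gives a second substituent on that nitrogen, 2-hydroxyethyl alongside benzyl, that stands beyond the scatter under the primary amide of compound 1, and none of the three compounds goes against this. Nothing at hand explains these numbers.

Open is whether any substituent on that nitrogen can match or pass compound 1, as only benzyl and 2-hydroxyethyl are shown. A methyl group, a terminal amine, a terminal carboxylic acid or a longer hydroxyalkyl chain there would test this.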